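The source may hold more compounds than are shown below. What is called first, only, known or untested is meant among the compounds shown, and "the series" means these compounds.

In a toxicity assay on MDCK cells (Canis lupus familiaris) for cytotoxicity, read by crystal violet staining, with a stated time of 48 h (on this read-out higher numbers stand for lower toxicity in this test and lower numbers for higher toxicity in this test), compound 2 `COc1ccc(CN(Cc2ccc(C(C)(C)C)cc2)Cc2cc3cc(C)ccc3[nH]c2=O)cc1` gives only a limit of > 10000 nM, not a number. Compound 1 `CCc1ccc2cc(CN(Cc3ccc(C(C)(C)C)cc3)C3CCCC3)c(=O)[nH]c2c1` likewise gives only a limit, > 9000 nM, in this assay. So both values shown are limits, one sitting at the limit of > 10000 nM in this assay, at which 1 of the 2 values shown sits, and one at the limit of > 9000 nM in this assay, at which 1 of the 2 values shown sits, and no measured step between compounds exists. Compound 3 `Cc1ccc2[nH]c(=O)c(CN(Cc3ccc(C(C)(C)C)cc3)[C@H](CO)c3ccccc3)cc2c1` has not yet been tested in this assay. It differs from compound 2 by 2-hydroxy-1-phenylethyl in place of 4-methoxybenzyl on an amine nitrogen. No change beyond the usual scatter is expected, and the expected step is a number no higher from compound 2 to compound 3 (the limit leaves the size open). Compound 3 is estimated to give 10000 nM, within a range of 5000 nM to 20000 nM, most likely again as a limit.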

Compound 3, half-maximal cytotoxic concentration: > 10000 nM
Compound 3 was reported as a limit; the forecaster's own chance of this, stated with the estimate: 80%; the middle value sits exactly at the limit.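

Within the data shown here, compound 2 and compound 3 are both reported only as limits, so no step between them can be read. The compounds shown leave open at what concentration any of them turns toxic, and whether 2-hydroxy-1-phenylethyl in place of 4-methoxybenzyl changes that.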